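Compound 1 to compound 3: an added methyl

A few compounds are considered here, and "the series" means these few. Any claim that something is new, unique, unknown or untested is made for them only; others in the source may bear on it.

In a physicochemical assay for solubility, read by HPLC, at pH 6.8 (a higher number here means a more soluble compound, a lower number a less soluble compound), compound 1 (`COCCNC(=O)c1cnn(-c2cccc3cc(Cc4cccc(C(F)(F)F)c4)sc23)c1`) gives < 0.08 ug/mL, which is a limit and not a number. Compound 2 (`O=C(NCCO)c1cnn(-c2cccc3cc(Cc4cccc(C(F)(F)F)c4)sc23)c1`) also gives only a limit, < 0.09 ug/mL. Compound 3 (`COCCNC(=O)c1cn(-c2cccc3cc(Cc4cccc(C(F)(F)F)c4)sc23)nc1C`) differs from compound 1 by methyl in place of hydrogen on an aromatic carbon, with methyl in place of hydrogen on an aromatic carbon. Among the compounds with values here, the one measured step is a step that the two limits leave unreadable from compound 1 to compound 2, and it concerns another part of the structure, so it offers no size to carry over. No step beyond the scatter is expected, and the estimated step is a step that the limit leaves unreadable from compound 1 to compound 3. For compound 3 the expected value is 0.06 ug/mL, with an estimated range of 0.02 ug/mL to 0.15 ug/mL.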

Compound 3, solubility: < 0.1 ug/mL
Compound 3: a limit, no number (the forecaster's own chance of this, stated with the estimate: 85%); the middle value lies beyond the limit too.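

In this assay, within the data shown here, compound 1 and compound 3 both give limits rather than numbers, so no step between them can be read. Going by these compounds, the size and direction of any change from the added methyl remain open.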